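Methoxy for Methyl on Two Thiophene-Bearing Cores

The source may hold more compounds than are shown below. What is called first, only, known or untested is meant among the compounds shown, and "the series" means these compounds.

The study measures glioma cell inhibition in a functional assay on U-373MG ATCC cells (Homo sapiens) for inhibition, read by colorimetric assay and MTT assay, with a stated time of 72 h; on this read-out higher numbers stand for weaker inhibition and lower numbers for stronger inhibition. Compound 1 `Cc1ccc(C(=O)NNC(=S)Nc2csc(-c3ccc(C)cc3)c2)cc1` gives 38000 nM in this assay. Compound 2 `COc1ccc(C(=O)NNC(=S)Nc2csc(-c3ccc(C)cc3)c2)cc1` gives 19000 nM in this assay. The change between them, (methoxy in place of methyl on an aromatic carbon), gave a 2.0-fold lower number from compound 1 to compound 2 (0.30 log units; within the scatter).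

Compound 3 `Cc1ccc(-c2nnc(Nc3csc(-c4ccccc4)c3)s2)cc1` carries a different core, and the difference between the two cores is not broken down here. In this assay compound 3 reaches only a limit, > 100000 nM, not a number; this is the limit of > 100000 nM in this assay, at which 1 of the 3 values shown sits.

Compound 4 `COc1ccc(-c2nnc(Nc3csc(-c4ccccc4)c3)s2)cc1` has not yet been measured. It differs from compound 3 by methoxy in place of methyl on an aromatic carbon, the same change seen from compound 1 to compound 2. On the earlier pair that change stayed within scatter, so a similarly small step is expected, a number no higher from compound 3 to compound 4 (the limit leaves the size open), resting on the step from compound 1 to compound 2. Since compound 3 sits at the limit, compound 4 is expected to land near 100000 nM, likely again reported only as a limit, within a range from 40000 nM to 300000 nM.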

Compound 4, half-maximal inhibitory concentration: 92000 nM
For compound 4 the middle estimate is 1.1-fold (0.04 log units) above the measured one; the range from low to high includes it.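

In this assay, replacing methyl with methoxy on the core of compound 3, the change from 4-methylphenyl to 4-methoxyphenyl, gave an at least 1.0-fold lower number from compound 3 to compound 4 (0.03 log units; that floor lies within the scatter). For compound 3 the value > 100000 nM is a limit of the assay and not a number. The new step is therefore compatible with the earlier one, but it does not show that the size of the step carries from one core to the other, and with only two pairs, the earlier one within the scatter, it does not establish a transferable gain: the same change on two cores in this assay, a 2.0-fold lower number (0.30 log units; within the scatter) from compound 1 to compound 2 and an at least 1.0-fold lower number (0.03 log units; that floor lies within the scatter) from compound 3 to compound 4; the limit leaves it open whether they differ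

The compounds shown leave open how other groups on the same aromatic carbon, such as an amine, a carboxylic acid or a longer alkoxy chain, would read in this assay. They also leave open whether methoxy in place of methyl would give a step beyond the scatter on any core.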